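The source may hold more compounds than are shown below. What is called first, only, known or untested is meant among the compounds shown, and "the series" means these compounds.

In a functional assay on HeLa cells (Homo sapiens) for antiproliferative activity, read by MTT assay, with a stated time of 48 h (on this read-out higher numbers stand for weaker inhibition and lower numbers for stronger inhibition), three compounds have been measured so far:
Compound 1 `O=[N+]([O-])c1cccc(-c2nn(-c3ccccc3)cc2C(Nc2nc3ccccc3s2)c2c(O)ccc3ccccc23)c1` gives 8220 nM
Compound 2 `Cc1ccc2nc(NC(c3cn(-c4ccccc4)nc3-c3cccc(Cl)c3)c3c(O)ccc4ccccc34)sc2c1` gives 9430 nM
Compound 3 `Oc1ccc2ccccc2c1C(Nc1nc2ccccc2s1)c1cn(-c2ccccc2)nc1-c1ccccc1` gives 17300 nM

Compound 3 lies within the usual scatter of compound 2 but beyond the scatter from compound 1. Compound 4 `Oc1ccc2ccccc2c1C(Nc1nc2ccccc2s1)c1cn(-c2ccccc2)nc1-c1ccc(I)cc1` has iodo in place of hydrogen on an aromatic carbon, para to a large group iodo in place of hydrogen on an aromatic carbon and no other change. For the measured compounds named here, the one measured step that bears on this is a 2.1-fold higher number from compound 1 to compound 3 (0.32 log units; beyond the scatter) and it is modest. Read in reverse, that step links a nitro group in place of hydrogen with a lower number. A single step with a different group is thin evidence, so only a small move toward a lower number is expected in this assay here. The expected step is a 1.6-fold lower number from compound 3 to compound 4 (0.20 log units; within the scatter) and it may not be seen at all. For compound 4 the estimated value is 11000 nM with an expected range of 4500 nM to 26000 nM in this read-out.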

Compound 4, half-maximal inhibitory concentration: 6590 nM
Estimate against measurement, compound 4: 1.7-fold (0.22 log units) above; the range from low to high includes it.
By their numbers in this assay, from the lowest: compounds 4, 1, 2 and 3 (each within the scatter of the next, the first and the last beyond it).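

In this assay the change from phenyl to 4-iodophenyl gives a 2.6-fold lower number from compound 3 to compound 4 (0.42 log units; beyond the scatter) and shows that one iodine atom at this place, para to a large group, is enough to move the number beyond the scatter. Replacing 3-nitrophenyl with 4-iodophenyl gives a 1.2-fold lower number from compound 1 to compound 4 (0.10 log units; within the scatter) and stays within the scatter, so this assay does not separate these two groups. Nothing measured here gives a cause for the iodo step.

As far as these compounds go, whether iodo itself matters, or any group at this place would serve, stays open. Fluoro, methoxy or an amine at this place could help to settle that.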